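The compounds below may be only part of what the source reports. "The series", "measured", "known", "first", "only" and "open" are said of these compounds alone.

Compound 1 `Cc1ccc(C(CCn2ccnc2C)(C(N)=O)c2ccccc2)cc1` and compound 2 `Cc1nccn1CCC(C)(C(N)=O)c1ccccc1` have been measured. In an assay on ileum with muscarinic acetylcholine receptor M3 (Cavia porcellus) as the target (a higher number here means a weaker inhibitor, a lower number a stronger inhibitor), compound 1 gives 24.6 nM and compound 2 gives 1830 nM.

Compound 2 stands as the highest of the two numbers. For the measured compounds named here, the only step bearing on it is a 74-fold higher number from compound 1 to compound 2 (1.87 log units; beyond the scatter), a large loss of strength when the 4-methylphenyl shrank to methyl. Compound 3 `Cc1nccn1CCC(C(N)=O)(c1ccccc1)C(C)C` differs from compound 2 by isopropyl in place of methyl on a saturated chain carbon bound to an aromatic carbon, a carbonyl carbon and a saturated chain carbon. Isopropyl is larger than methyl, so a partial recovery is expected. The step of a 3.7-fold lower number from compound 2 to compound 3 (0.56 log units; beyond the scatter) is estimated in this assay. Compound 3 is expected at 500 nM, between 100 nM and 2000 nM.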

Compound 3, antagonist equilibrium constant: 394 nM
Compound 3: middle estimate off by 1.3-fold (0.10 log units), on the high side, and the stated range covers the measured number.
By their numbers in this assay, from the lowest: compound 1; then compound 3; then compound 2.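

In this assay, isopropyl on this saturated chain carbon wins back only part of what methyl lost: the change gives a 4.6-fold lower number from compound 2 to compound 3 (0.67 log units; beyond the scatter) but still leaves a 16-fold higher number from compound 1 to compound 3 (1.20 log units; beyond the scatter) as the remaining gap. Across these three compounds, the number falls from methyl to isopropyl to 4-methylphenyl, and none goes against that order. Nothing available explains why this position responds in this way.

Going by these compounds, whether cyclohexyl or a longer chain such as butyl on this carbon would bring the number closer to that of compound 1 remains open.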